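The source may hold more compounds than are shown below. What is called first, only, known or untested is meant among the compounds shown, and "the series" means these compounds.

Working notes on the series. Among the measured compounds shown here, in an assay on isolated protein with Bile acid receptor (Homo sapiens) as the target (a lower number here means that less compound is needed, a higher number that more compound is needed for the effect), compound 3 `COC(=O)/C=C/c1cccc(N(Cc2ccc(-c3cccc(OC)c3)cc2)C(=O)NC(C)C)c1` gives 1370 nM, the largest number of the three so far; compound 1 `COC(=O)/C=C/c1cccc(N(Cc2ccc(/C=C/c3cccc(C(F)(F)F)c3)cc2)C(=O)NC(C)C)c1` gives 932 nM in this assay, and compound 2 `COC(=O)/C=C/c1cccc(N(Cc2ccc(/C=C/c3cccc(F)c3)cc2)C(=O)C(C)C)c1` gives 71 nM, which is well apart from compound 3 but differs from it in two places, so no single-change step is available there. Compound 4 `COC(=O)/C=C/c1cccc(N(Cc2ccc(-c3ccc(N(C)C)cc3)cc2)C(=O)NC(C)C)c1` carries 4-(dimethylamino)phenyl in place of 3-methoxyphenyl on an aromatic carbon. For the measured compounds named here, the only measured step touching this position, a 1.5-fold higher number from compound 1 to compound 3 (0.17 log units; within the scatter), was within the scatter, and no measured step covers an exchange of one aryl group for another. The expected step is therefore a 1.1-fold lower number from compound 3 to compound 4 (0.02 log units; within the scatter), none beyond the scatter. Compound 4 is estimated at 1300 nM, in a range of 400 nM to 4200 nM.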

Compound 4, half-maximal effective concentration: 162 nM
Compound 4: the middle estimate sits 8.0-fold (0.90 log units) above what was measured; the measured number lies below the stated range.
By their numbers in this assay, from the lowest: compound 2; then compound 4; then compounds 1 and 3 (each within the scatter of the next).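

In this assay, the aryl group at this position is not interchangeable: the exchange of 3-methoxyphenyl for 4-(dimethylamino)phenyl gives an 8.5-fold lower number from compound 3 to compound 4 (0.93 log units; beyond the scatter), whereas the earlier step here stayed within the scatter. Replacing 2-(3-(trifluoromethyl)phenyl)ethenyl with 4-(dimethylamino)phenyl likewise gives a 5.8-fold lower number from compound 1 to compound 4 (0.76 log units; beyond the scatter), so this position can respond to the group it carries. Nothing available explains the size of these steps.
The group and its place on the ring change together between compound 3 and compound 4, so their shares remain unseparated. 3-(Dimethylamino)phenyl or 4-methoxyphenyl would divide them.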